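One Methyl Restored on a Symmetric Pair

The compounds below may be only part of what the source reports. "The series", "measured", "known", "first", "only" and "open" are said of these compounds alone.

Among the three compounds measured, compound 3 `N/C(=N\C(=O)CCCCCCCCC(=O)/N=C(\N)NCCCc1cnc(N)s1)NCCCc1cnc(N)s1` stands second highest: in an in vitro functional assay on Sf9 cells for agonist activity at histamine H2 receptor (Homo sapiens) (on this read-out lower numbers stand for an effect already at smaller amounts and higher numbers for an effect only at larger amounts of compound), compound 3 gives 21.4 nM. Its nearest neighbour, compound 1 `Cc1nc(N)sc1CCCN/C(N)=N/C(=O)CCCCC(=O)/N=C(\N)NCCCc1sc(N)nc1C`, gives 57.5 nM in this assay, a number beyond the scatter above it, while compound 2 `Cc1nc(N)sc1CCCN/C(N)=N/C(=O)CCCCCCCCC(=O)/N=C(\N)NCCCc1sc(N)nc1C` gives 7.76 nM, beyond the scatter below it. Compound 4 `Cc1nc(N)sc1CCCN/C(N)=N/C(=O)CCCCCCCCC(=O)/N=C(\N)NCCCc1cnc(N)s1` differs from compound 3 in one place: methyl in place of hydrogen on an aromatic carbon. For the measured compounds named here, no measured pair isolates this single change; compound 3 and compound 2 differ by two such methyls, and their values show a lower number for the doubly substituted compound. A modest step downward, beyond the scatter, is therefore expected; this step is estimated as a 1.8-fold lower number from compound 3 to compound 4 (0.25 log units; within the scatter). Compound 4 is expected to give 12 nM, with a range from 5 nM to 30 nM.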

Compound 4, half-maximal effective concentration: 13.8 nM
Estimate against measurement, compound 4: 1.2-fold (0.06 log units) below, and the stated range covers the measured number.
By their numbers in this assay, from the lowest: compounds 2, 4 and 3 (each within the scatter of the next, the first and the last beyond it); then compound 1.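

In this assay, with the long chain kept, methyl in place of hydrogen on one end gives a 1.6-fold lower number from compound 3 to compound 4 (0.19 log units; within the scatter) and hydrogen in place of methyl gives a 1.8-fold higher number from compound 2 to compound 4 (0.25 log units; within the scatter) as the pair's other neighbour. A single change from 2-amino-1,3-thiazol-5-yl to 2-amino-4-methyl-1,3-thiazol-5-yl therefore cannot be told from the scatter, whichever partner it is read against. No measurement here speaks to the reason for these steps.

Going by these compounds, whether an ethyl group or a chlorine on that carbon would read like methyl remains open. So does whether one methyl reads the same with the shorter chain of compound 1.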